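Swapping iodo for nitro on the 4-phenyl group

A few compounds are considered here, and "the series" means these few. Any claim that something is new, unique, unknown or untested is made for them only; others in the source may bear on it.

Measured so far in a functional assay on MCF7 cells (Homo sapiens) for antiproliferative activity, read by MTT assay, with a stated time of 48 h; a lower number here means a stronger inhibitor, a higher number a weaker inhibitor
- compound 1 `Cc1cc2nc(NC(c3cn(-c4ccccc4)nc3-c3ccc([N+](=O)[O-])cc3)c3c(O)ccc4ccccc34)sc2cc1C` gives 41100 nM
- compound 2 `COc1ccc2nc(NC(c3cn(-c4ccccc4)nc3-c3ccc([N+](=O)[O-])cc3)c3c(O)ccc4ccccc34)sc2c1` gives 13300 nM
- compound 3 `Oc1ccc2ccccc2c1C(Nc1nc2ccc(Cl)cc2s1)c1cn(-c2ccccc2)nc1-c1ccc(I)cc1` gives 65000 nM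

The number for compound 3 lies within the usual scatter of the number for compound 1, and both stand clearly above the number for compound 2. The next compound to be tested in this assay is compound 4 `O=[N+]([O-])c1ccc(-c2nn(-c3ccccc3)cc2C(Nc2nc3ccc(Cl)cc3s2)c2c(O)ccc3ccccc23)cc1` and it has nitro in place of iodo on an aromatic carbon, para to a large group nitro in place of iodo on an aromatic carbon while the rest of compound 3 stays the same.

For the measured compounds named here, no measured step makes this exact swap. Going by the values given here, the only measured step is a 3.1-fold lower number from compound 1 to compound 2 (0.49 log units; beyond the scatter) and it lies elsewhere in the molecule, so it shows only how far one modest change has moved the number. Compound 1 and compound 2 do carry the 4-nitrophenyl group found in compound 4, but each differs from compound 4 at the other end of the molecule. Their values therefore offer only a loose guide, and they point to a modest move toward a lower number.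

The expected change is a 2.2-fold lower number from compound 3 to compound 4 (0.34 log units; beyond the scatter) (an estimate, and the range still allows for no real change). For compound 4 the estimated value is 30000 nM (expected range 11000 nM to 70000 nM).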

Compound 4, half-maximal inhibitory concentration: 38600 nM
Compound 4: the middle estimate sits 1.3-fold (0.11 log units) below what was measured, and the stated range covers the measured number.
By their numbers in this assay, from the lowest: compound 2; then compounds 4, 1 and 3 (each within the scatter of the next).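

In this assay, going from 4-iodophenyl to 4-nitrophenyl gives a 1.7-fold lower number from compound 3 to compound 4 (0.23 log units; within the scatter), so this position does not separate the two groups, even though nitro brings more heavy atoms and hydrogen-bond acceptors, while iodo brings no acceptors at all. Compound 4 also allows the other end of the molecule to be compared with the 4-nitrophenyl group held fixed: 6-chloro-1,3-benzothiazol-2-yl in place of 5,6-dimethyl-1,3-benzothiazol-2-yl gives a 1.1-fold lower number from compound 1 to compound 4 (0.03 log units; within the scatter), whereas chloro in place of methoxy gives a 2.9-fold higher number from compound 2 to compound 4 (0.46 log units; beyond the scatter), so among these three compounds only the methoxy of compound 2 stands apart. No measurement offered here accounts for either the lack of separation or the methoxy gap.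

A single swap at this position cannot show whether an amine or a carboxylic acid on the same aromatic carbon would stand apart from iodo and nitro. From the compounds shown here alone, it also remains open whether methoxy on the far end would keep its gap from chloro if the 4-iodophenyl group replaced the 4-nitrophenyl group.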